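Swapping one five-membered ring for another on the shared core

The source may report more compounds than this note shows. Statements on the series, on what has been measured and on what is new or still open speak of the compounds shown alone.

Among the compounds with values here, only two numbers exist so far, and they sit within the scatter of each other: in a functional assay on aorta (strain Wistar) for inhibition, with Thoracic aorta (Rattus norvegicus) as the target (on this read-out lower numbers stand for stronger inhibition and higher numbers for weaker inhibition), compound 2 `CCOc1nc(-c2cc3ccccc3o2)cc(-c2cccs2)c1C#N` gives 308000 nM, and compound 1 `CCOc1nc(-c2cc3ccccc3o2)cc(-c2ccc(N(C)C)cc2)c1C#N` gives 338000 nM. Compound 3 `CCOc1nc(-c2cc3ccccc3o2)cc(-c2ccc(C)o2)c1C#N` carries 5-methylfuran-2-yl in place of thiophen-2-yl on an aromatic carbon. Within the data shown here, the one measured step that bears on this change is a 1.1-fold lower number from compound 1 to compound 2 (0.04 log units; within the scatter), where one aromatic group replaced another at the same carbon without any shift beyond the scatter. No step beyond the scatter is therefore expected in this assay. Compound 3 is estimated at 300000 nM, with a range from 130000 nM to 700000 nM. This amounts to an expected step of a 1.0-fold lower number from compound 2 to compound 3 (0.01 log units; within the scatter).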

Compound 3, half-maximal inhibitory concentration: 417000 nM
Compound 3: the middle estimate sits 1.4-fold (0.14 log units) below what was measured; measured number inside the range.
By their numbers in this assay, from the lowest: compounds 2, 1 and 3 (each within the scatter of the next).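

In this assay putting 5-methylfuran-2-yl on this carbon gives a 1.4-fold higher number from compound 2 to compound 3 (0.13 log units; within the scatter) and, set against the 4-(dimethylamino)phenyl group, gives a 1.2-fold higher number from compound 1 to compound 3 (0.09 log units; within the scatter) for the same swap. A third aromatic group, now a five-membered ring with oxygen and a methyl, thus still leaves the number within the scatter of the other two. Nothing on hand explains this lack of movement. On these data alone, whether a non-aromatic group here, such as an amine or a carboxylic acid, would shift the number beyond the scatter stays open. So does the role of the ethoxy group and the nitrile.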